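From 3,5-dimethylphenyl to phenyl on a carbonyl carbon

The source may report more compounds than this note shows. Statements on the series, on what has been measured and on what is new or still open speak of the compounds shown alone.

Two related compounds have been tested so far in an ADME assay on MT4 cells (Homo sapiens) for cytotoxicity, read by MTT assay, with a stated time of 4 days; on this read-out lower numbers stand for higher toxicity in this test and higher numbers for lower toxicity in this test. Among the compounds with values here, compound 2 `Cc1cc(C)cc(C(=O)c2cc(C)ccc2OCCn2ccc(=O)[nH]c2=O)c1` gives 179000 nM, the only actual number available. Compound 1 `O=C(c1ccccc1)c1cc(Br)ccc1OCCn1ccc(=O)[nH]c1=O` gives > 301000 nM, which is a limit of the assay and not a number. Compound 2 therefore stands alone, with no second number to compare it against.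

The next compound, compound 3 `Cc1ccc(OCCn2ccc(=O)[nH]c2=O)c(C(=O)c2ccccc2)c1`, changes compound 2 in one place, with phenyl in place of 3,5-dimethylphenyl on a carbonyl carbon. Within the data shown here, no pair of measured compounds differing in one place exists yet, so this change has no direct precedent in this assay. Compound 1 also carries phenyl on a carbonyl carbon, and its > 301000 nM is again a limit, so it offers only a loose guide.

The expected step of a 1.4-fold higher number from compound 2 to compound 3 (0.15 log units; within the scatter) is not expected to go beyond the usual scatter. For compound 3 the estimate is 250000 nM, with an expected range from 110000 nM to 400000 nM.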

Compound 3, half-maximal cytotoxic concentration: > 357000 nM
Compound 3: only a limit was reported; the forecaster's own chance of this, stated with the estimate: 40%; middle value at least 1.4-fold (0.15 log units) from the limit.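

In this assay, within the data shown here, this is the first comparison of two compounds that differ in one place, and phenyl in place of 3,5-dimethylphenyl on a carbonyl carbon gives an at least 1.9-fold higher number from compound 2 to compound 3 (0.29 log units; that floor lies within the scatter). As far as these compounds go, compound 3 gives > 357000 nM, which is a limit of the assay and not a number, so the true size of this step stays unknown. The smallest step the limit allows lies within the usual scatter, so the pair shows no firm change; it shows only that the plain phenyl gave no lower number in this test than the 3,5-dimethylphenyl group.

The step from compound 1 to compound 3, methyl in place of bromo on an aromatic carbon, cannot be read, as both values are limits and neither gives a number to measure from. Also open, from the compounds shown here alone, is how this test would read with a carboxylic acid in place of phenyl on a carbonyl carbon, a change that would show whether anything at this place can bring the number down.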